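This account rests on a few compounds, and the source may have more. Where it says the series, first, only, none or still open, it means among the compounds named here.

Compound 1 `COc1ccc(C[C@H]2COC(=O)[C@@H]2Cc2ccc(OCc3cn(Cc4ccc(Cl)cc4)nn3)c(OC)c2)cc1OC`: 242000 nM
Compound 2 `COc1ccc(C[C@H]2COC(=O)[C@@H]2Cc2ccc(OCc3cn(Cc4ccccc4)nn3)c(OC)c2)cc1OC`: 346000 nM

In an ADME assay on HeLa cells (Homo sapiens) for cytotoxicity, read by MTT assay (on this read-out lower numbers stand for stronger inhibition and higher numbers for weaker inhibition), compound 2 gives 346000 nM, within the scatter of compound 1. Compound 3 `COc1ccc(-n2cc(COc3ccc(C[C@H]4C(=O)OC[C@@H]4Cc4ccc(OC)c(OC)c4)cc3OC)nn2)cc1` differs from compound 2 by one change: 4-methoxyphenyl in place of benzyl on an aromatic nitrogen. For the measured compounds named here, the only measured step, a 1.4-fold higher number from compound 1 to compound 2 (0.16 log units; within the scatter), lies within the scatter and involves a different exchange, so it is only an indirect guide. On that slender evidence, no shift beyond the scatter is expected in this assay, in either direction. The expected change is a 1.2-fold lower number from compound 2 to compound 3 (0.09 log units; within the scatter). For compound 3 the estimate is 280000 nM, with an expected range of 120000 nM to 600000 nM.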

Compound 3, half-maximal inhibitory concentration: >= 600000 nM
Compound 3 gave a limit, no number (the forecaster's own chance of this, stated with the estimate: 10%); at least 2.1-fold (0.33 log units) between middle value and limit.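

In this assay compound 3 gives no number, only a limit: the limit of >= 600000 nM in this assay, at which 1 of the 3 values shown sits.

On the aromatic nitrogen, the exchange gives an at least 1.7-fold higher number from compound 2 to compound 3 (0.23 log units; that floor lies within the scatter), so the shift against benzyl stays unsettled. Against 4-chlorobenzyl it gives an at least 2.4-fold higher number from compound 1 to compound 3 (0.39 log units; beyond the scatter), the first step at this position that is printed as beyond the scatter.

On these data alone, how far compound 3 lies past its limit remains open, as does whether the methoxy or the loss of the benzyl carbon carries the step. Also open, as far as these compounds go, is what an amine, a carboxylic acid or a longer chain would do at this position.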